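The source may hold more compounds than are shown below. What is called first, only, known or untested is meant among the compounds shown, and "the series" means these compounds.

Measured compounds:
compound 1 `CC(=O)OC[C@H]1O[C@@H](OCc2noc(-c3ccc([N+](=O)[O-])cc3)n2)[C@@H]2OC3(CCCC3)O[C@@H]21` gives 36000 nM
compound 2 `CC1(C)O[C@H]2[C@H](OCc3noc(-c4ccc([N+](=O)[O-])cc4)n3)O[C@H](CSc3nnc(N)s3)[C@H]2O1` gives > 100000 nM

Among the measured compounds shown here, in a functional assay on WiDr cells (Homo sapiens) for antiproliferative activity, read by sulforhodamine B assay, with a stated time of 48 h (a lower number here means a stronger inhibitor of growth, a higher number a weaker inhibitor of growth), compound 1 gives 36000 nM, the only number among the two measured compounds. Compound 2, which carries the same ((5-amino-1,3,4-thiadiazol-2-yl)sulfanyl)methyl group on a different acetal, reaches only (the limit of > 100000 nM in this assay, at which 1 of the 2 values shown sits); that figure is a limit of the assay, not a number. The unmeasured compound 3 `Nc1nnc(SC[C@H]2O[C@@H](OCc3noc(-c4ccc([N+](=O)[O-])cc4)n3)[C@@H]3OC4(CCCC4)O[C@@H]32)s1` is compound 1 with one change: (5-amino-1,3,4-thiadiazol-2-yl)sulfanyl in place of acetoxy on a saturated chain carbon bound to a saturated ring carbon. For the measured compounds named here, no measured pair isolates this change, so its size can only be guessed, and the one compound that already bears the entering group gave no number at all. In this assay compound 3 is expected to come out weaker than compound 1, with a 2.2-fold higher number from compound 1 to compound 3 (0.35 log units; beyond the scatter) as the likely step, and a fair chance that only a limit is reported. Compound 3 is therefore estimated at 80000 nM, within 30000 nM to 200000 nM.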

Compound 3, concentration for 50% growth inhibition: 26000 nM
For compound 3 the middle estimate is 3.1-fold (0.49 log units) above the measured one; the whole stated range lies above it.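

In this assay, putting (5-amino-1,3,4-thiadiazol-2-yl)sulfanyl in place of acetoxy on a saturated chain carbon bound to a saturated ring carbon gives a 1.4-fold lower number from compound 1 to compound 3 (0.14 log units; within the scatter), so this position takes the larger group with no change that can be told from the scatter. Among the compounds shown here, compound 3 also shows that the entering group can give a real number on the core of compound 1, which the earlier compounds did not show. Compound 2, with the same group on a different acetal, gave a limit of the assay and not a number: the limit of > 100000 nM in this assay, at which 1 of the 3 values shown sits.

The compounds shown leave open whether an amine, a carboxylic acid or a longer chain at this position would stay within the scatter of compound 1. They also leave open how far the result depends on the acetal: compound 2 and compound 3 differ there, and only compound 3 gives a number.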